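Chlorine position on the benzyl sulfanyl arm across two cores

The source may hold more compounds than are shown below. What is called first, only, known or untested is meant among the compounds shown, and "the series" means these compounds.

Compound 1 `CC1=C(C(=O)Nc2ccc(Br)cc2)C(c2ccc(Cl)cc2Cl)N=C(SCc2cccc(Cl)c2)N1` and compound 2 `CC1=C(C(=O)Nc2ccc(Br)cc2)C(c2ccc(Cl)cc2Cl)N=C(SCc2ccc(Cl)cc2)N1` share one core and differ in a single respect: 4-chlorophenyl in place of 3-chlorophenyl on a saturated chain carbon bound to a sulfur. In a functional assay on the whole organism (artery, strain albino) with Rattus norvegicus as the target, with a stated time of 600 min, at a dose of 10 mg/kg by the oral route (a lower number here means less inhibition, a higher number more inhibition at the dose given (going by the name of the read-out)), compound 1 gives 15.4% and compound 2 gives 30.3%, which is a number 14.9 percentage points higher from compound 1 to compound 2 (beyond the scatter). Compound 3 `CC1=C(C(=O)Nc2ccc([N+](=O)[O-])cc2)C(c2ccc(Br)cc2)N=C(SCc2cccc(Cl)c2)N1` rests on a different core; the difference between the two cores is not broken down here. In this assay compound 3 gives 5.1%, the lowest of the three numbers, and its gaps to compound 1 and to compound 2 both lie beyond the scatter. Compound 4 `CC1=C(C(=O)Nc2ccc([N+](=O)[O-])cc2)C(c2ccc(Br)cc2)N=C(SCc2ccc(Cl)cc2)N1` is not yet measured; it stands to compound 3 exactly as compound 2 stands to compound 1: 4-chlorophenyl in place of 3-chlorophenyl on a saturated chain carbon bound to a sulfur. This change occurs twice among the compounds shown, once measured and once not. For the measured compounds named here, from compound 3, compound 4 is expected to rise by a number 14.9 percentage points higher from compound 3 to compound 4 (beyond the scatter), set beside the earlier step, because the one measured instance a number 14.9 percentage points higher from compound 1 to compound 2 (beyond the scatter) is the only guide available. That instance sits on one core only, so the expectation is held loosely. Compound 4 is estimated at 20%, with a range from 8% to 32%.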

Compound 4, a percentage reported as inhibition, in the whole organism at one dose (the size of the read-out at that dose, not a potency): 34.4%
Estimate against measurement, compound 4: 14.4 percentage points below; measured number above the stated range.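

In this assay, 4-chlorophenyl in place of 3-chlorophenyl on a saturated chain carbon bound to a sulfur gives a number 29.3 percentage points higher from compound 3 to compound 4 (beyond the scatter), so the direction of the step seen on the core of compound 1 also holds on the core of compound 3. The direction carries over from one core to the other, but the size of the step does not: the same change on two cores in this assay, a number 14.9 percentage points higher (beyond the scatter) from compound 1 to compound 2 and a number 29.3 percentage points higher (beyond the scatter) from compound 3 to compound 4, 14.4 percentage points apart, beyond the scatter of two such steps

These are only two instances, and the difference in the cores is not broken down, so the compounds do not show which part of that difference goes with the larger step, nor how the change would behave on a third core. Still open, as far as these compounds go, is whether the same ordering would hold with an unsubstituted benzyl, a methoxybenzyl or a longer phenethyl chain on the sulfur. Also open, from the compounds shown here alone, is whether it would hold on a core carrying an amine or a carboxylic acid, and, with a single oral dose as the only read-out, whether these steps reflect any difference in potency.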